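The compounds below may be only part of what the source reports. "The series", "measured", "known", "first", "only" and "open" are said of these compounds alone.

Measured so far in a functional assay on the whole organism (strain NMRI) with Mus musculus as the target, with a stated time of 0.5 h; on this read-out lower numbers stand for an effect already at smaller amounts and higher numbers for an effect only at larger amounts of compound:

compound 1, `C#CCO/N=C/c1c(-c2ccc(C)cc2)nc2ccc(Br)cn12`, gives 20 mg/kg
compound 2, `Cc1ccc(-c2nc3ccc(Br)cn3c2/C=N/O)cc1`, gives 20 mg/kg
compound 3, `Cc1ccc(-c2nc3ccc(Br)cn3c2/C=N/OCc2cn(Cc3ccc([N+](=O)[O-])cc3)nn2)cc1`, gives 20 mg/kg

Compound 1 stands level with compound 2 and compound 3 on these numbers. For the measured compounds named here, the only measured step among them, hydrogen in place of propargyl on an oxygen, no change at the digits printed from compound 1 to compound 2 (within the scatter). Compound 1 and compound 3 carry different groups on that same oxygen and still show the same value, so the three measured compounds give no sign that the substituent on the oxygen moves the read-out.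

Compound 4, `C#CCO/N=C/c1c(-c2ccc(F)cc2)nc2ccc(Br)cn12`, has not been measured. It differs from compound 1 in one place: fluoro in place of methyl on an aromatic carbon. Going by the values given here, no measured step touches the 4-methylphenyl, so nothing among the measured compounds bears directly on this change, and the shared core carrying the oxime is unaltered. With no evidence for movement in either direction, the expected step of no change at the digits printed from compound 1 to compound 4 (within the scatter) is none beyond the scatter. Compound 4 is therefore estimated at 20 mg/kg in this assay, within a range of 10 mg/kg to 40 mg/kg.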

Compound 4, minimum effective dose: 40 mg/kg
Beside the measured number, compound 4's estimate is 2.0-fold (0.30 log units) below it, within the range that was stated.
By their numbers in this assay, from the lowest: compounds 1, 2, 3 and 4 (each within the scatter of the next).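

In this assay, for the compounds shown here, a step of a 2.0-fold higher number from compound 1 to compound 4 (0.30 log units; within the scatter) is the first reading on the 4-methylphenyl, since the earlier compounds differ only in the group on the oxygen. It shows that fluoro in place of methyl, on an aromatic carbon para to a large group, gives no movement that can be told from the scatter. That holds for this one exchange, on the propargyl compounds only. Nothing measured here accounts for the result or tells what either group does at this position.

Still open, on these data alone, is whether an amine, a carboxylic acid or a longer chain in place of the methyl would move the read-out beyond the scatter. Also open, as far as these compounds go, is whether the same exchange would read alike with the oxygen groups of compound 2 and compound 3.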